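The source may report more compounds than this note shows. Statements on the series, on what has been measured and on what is new or still open speak of the compounds shown alone.

Compound 1 `ClCc1ccc(Cn2cnc3c(Cl)ncnc32)cc1` was tested in a functional assay on KM12 cells (Homo sapiens) for cytotoxicity, read by sulforhodamine B assay, with a stated time of 48 h (a lower number here means a stronger inhibitor of growth, a higher number a weaker inhibitor of growth), where compound 1 gives 10200 nM. Among the three measured compounds this is the second highest number. Its nearest neighbour is compound 3 `ClCc1ccccc1Cn1cnc2ncnc(Cl)c21`, which gives 11200 nM, a difference within the usual scatter, so nothing separates the two. Furthest from it is compound 2 `ClCc1ccc(Cn2cnc3nc(Cl)nc(Cl)c32)cc1`, which gives 670 nM; the gap between compound 1 and compound 2 lies well beyond the scatter, and compound 2 is the one of the three whose core bears an additional chloro group.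

Compound 4 `ClCc1ccc(Cn2cnc3c(Cl)nc(Cl)nc32)cc1` is compound 1 with one change: chloro in place of hydrogen on an aromatic carbon. Among the measured compounds shown here, no directly comparable pair of measured compounds shows this change, so its size is uncertain. Since compound 2, with a chloro-enriched core, gives 670 nM, a step towards a lower number is expected for compound 4, though of unknown size. The expected step from compound 1 to compound 4 is a 6.8-fold lower number from compound 1 to compound 4 (0.83 log units; beyond the scatter). Compound 4 is therefore estimated at 1500 nM, within a range from 400 nM to 6000 nM.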

Compound 4, concentration for total growth inhibition: 3240 nM
Estimate against measurement, compound 4: 2.2-fold (0.33 log units) below; low and high end bracket the measured number.
By their numbers in this assay, from the lowest: compound 2; then compound 4; then compounds 1 and 3 (each within the scatter of the next).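

In this assay, among the compounds shown here, chloro in place of hydrogen on an aromatic carbon, at the place between two ring nitrogen atoms, gives a 3.1-fold lower number from compound 1 to compound 4 (0.50 log units; beyond the scatter) as the first step in this set that isolates one change. The step is modest but beyond the scatter, so this position takes a chloro group, meta to the chloro group already on the ring, and the number falls rather than rises. Nothing measured here accounts for why the number falls at this position. On these data alone, whether an amine, a methoxy group or a bromo group at this same place would give a lower or a higher number remains open. As far as these compounds go, it also remains open whether the same chloro change would give a step of similar size on compound 3.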